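The source may hold more compounds than are shown below. What is called first, only, known or untested is meant among the compounds shown, and "the series" means these compounds.

Within the data shown here, compound 1 `Cc1nn([C@H](C)c2ccc(Cl)cc2Cl)c2nc(N3CC[C@H](N4CCCC4)[C@H](C)C3)cnc12` is one of three compounds measured in a functional assay on cells for antagonist activity at C-C chemokine receptor type 4 (Homo sapiens), read by fluorescence and calcium flux, with stated times of 2.5 s and 45 s (a higher number here means a weaker inhibitor, a lower number a stronger inhibitor), where compound 1 gives 69 nM. This is the highest of the three numbers, though its gap to each of the other two is within the scatter: compound 2 `C[C@@H]1CC(c2cnc3c(C#N)nn([C@H](C)c4ccc(Cl)cc4Cl)c3n2)=CC[C@@H]1N1CCC[C@H]1CO` gives 40 nM in this assay, and compound 3 `Cc1nn([C@H](C)c2ccc(Cl)cc2Cl)c2nc(C3=CC[C@H](N4CCC[C@H]4CO)[C@H](C)C3)cnc12` gives 36 nM. Among the measured compounds shown here, the only single-point step among the measured compounds, a 1.1-fold lower number from compound 2 to compound 3 (0.05 log units; within the scatter), shows no change beyond the scatter. Compound 4 `Cc1nn([C@H](C)c2ccc(Cl)cc2Cl)c2nc(N3CC[C@H](N4CCC[C@H]4CCC#N)[C@H](C)C3)cnc12` differs from compound 1 by 2-cyanoethyl in place of hydrogen on a saturated ring carbon. For the measured compounds named here, no measured step covers a change of this kind. Compounds 2 and 3 carry a hydroxymethyl group on the same five-membered non-aromatic ring, but each differs from compound 1 in more than one place, so their values show only that a substituent on that ring is compatible with numbers near that of compound 1. Compound 4 is therefore expected to give a number close to that of compound 1. The expected step is a 1.4-fold lower number from compound 1 to compound 4 (0.14 log units; within the scatter), within the scatter. The estimate for compound 4 is 50 nM, with a range from 15 nM to 170 nM.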

Compound 4, half-maximal inhibitory concentration: 41 nM
Estimate against measurement, compound 4: 1.2-fold (0.09 log units) above; measured number inside the range.
By their numbers in this assay, from the lowest: compounds 3, 2, 4 and 1 (each within the scatter of the next).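

Placing 2-cyanoethyl in place of hydrogen on a saturated ring carbon, next to the ring nitrogen, gives in this assay a 1.7-fold lower number from compound 1 to compound 4 (0.23 log units; within the scatter), so this read-out shows no change from the substitution. Among these compounds, the hydroxymethyl compounds had already carried a substituent on this five-membered ring, but only alongside other differences from compound 1, whereas this pair differs in one place and gives the first direct reading of a change at this ring carbon: 2-cyanoethyl can stand there without moving the number beyond the scatter. No measurement offered here bears on why the number holds when the chain is added.

The compounds shown leave open whether other groups at this ring carbon, such as an aminoethyl chain, a carboxylic acid or a longer chain ending in a nitrile, would also keep the number in this range. They also leave open how hydroxymethyl and 2-cyanoethyl compare on this ring when everything else in the molecule is held the same.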